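From a Sulfur Link to an Oxygen Link

The compounds below may be only part of what the source reports. "The series", "measured", "known", "first", "only" and "open" are said of these compounds alone.

Three close relatives of one shared core have been measured in a functional assay for inhibition of sodium/hydrogen exchanger (Oryctolagus cuniculus); a higher number here means a weaker inhibitor, a lower number a stronger inhibitor. Compound 1 `Cc1cc(Br)c(S(C)(=O)=O)cc1C(=O)N=C(N)N` gives 12 nM. Compound 2 `CCSc1cc(C)c(C(=O)N=C(N)N)cc1S(C)(=O)=O` gives 5.9 nM, and compound 3 `Cc1cc(Sc2ccccc2Cl)c(S(C)(=O)=O)cc1C(=O)N=C(N)N` gives 14 nM. Compound 3 thus carries the highest of the three numbers; against compound 1 the difference is a 1.2-fold higher number from compound 1 to compound 3 (0.07 log units; within the scatter), which stays within the scatter, while against compound 2 the change is a 2.4-fold higher number from compound 2 to compound 3 (0.38 log units; beyond the scatter), a modest weakening that goes beyond the scatter.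

Compound 4 `Cc1cc(Oc2cccc(Cl)c2)c(S(C)(=O)=O)cc1C(=O)N=C(N)N` has not yet been measured. It differs from compound 3 in one place: 3-chlorophenoxy in place of (2-chlorophenyl)sulfanyl on an aromatic carbon. Among the measured compounds shown here, of the measured steps, the one from compound 2 to compound 3 is the closest relative of this change, since it also placed an aromatic ring on the sulfur, and it was modest, a 2.4-fold higher number from compound 2 to compound 3 (0.38 log units; beyond the scatter). The step of a 1.2-fold higher number from compound 1 to compound 3 (0.07 log units; within the scatter) shows that a larger group in this place can leave the number essentially unchanged. For the measured compounds named here, no measured pair tests 3-chlorophenoxy against (2-chlorophenyl)sulfanyl directly. The expectation for compound 4 is therefore a small step, a 1.1-fold higher number from compound 3 to compound 4 (0.03 log units; within the scatter), most likely within the scatter. Compound 4 is estimated at 15 nM, with a range from 6 nM to 40 nM.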

Compound 4, half-maximal inhibitory concentration: 21 nM
Estimate against measurement, compound 4: 1.4-fold (0.15 log units) below; the measured number falls inside the stated range.
By their numbers in this assay, from the lowest: compound 2; then compounds 1, 3 and 4 (each within the scatter of the next).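

In this assay the exchange of (2-chlorophenyl)sulfanyl for 3-chlorophenoxy comes out as a 1.5-fold higher number from compound 3 to compound 4 (0.18 log units; within the scatter) and so shows that this position, ortho to the methylsulfonyl group, can carry an oxygen-linked aromatic ring as well as a sulfur-linked one without a clear shift in the number. Compound 4 also stays level with the bromo compound, with a 1.8-fold higher number from compound 1 to compound 4 (0.24 log units; within the scatter) as the step, while the ethylsulfanyl group keeps its advantage, with a 3.6-fold higher number from compound 2 to compound 4 (0.55 log units; beyond the scatter) as a step beyond the scatter, so both chlorine-bearing aromatic groups now sit above compound 2. Why these numbers fall as they do is not explained by any information available here.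

The linking atom and the place of the chlorine changed together in this step, and the compounds shown do not separate the two; a 2-chlorophenoxy group would do so. Also open, from the compounds shown here alone, is how this position responds to a group of another kind, such as an amine or a longer chain like butylsulfanyl.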